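This account rests on a few compounds, and the source may have more. Where it says the series, first, only, none or still open, it means among the compounds named here.

Compound 1, with the structure `O=C(Nc1ccccc1)C1CCc2ccccc2N1`, gives 110000 nM in a functional assay on PC-3 cells (Homo sapiens) for cytotoxicity, read by sulforhodamine B assay, with a stated time of 72 h; on this read-out higher numbers stand for weaker inhibition of growth and lower numbers for stronger inhibition of growth. Compound 2, with the structure `O=C(Nc1ccccc1O)C1CCc2ccccc2N1`, carries a hydroxy group on the aromatic ring of the amide part and gives 4310 nM; that single change produced a 26-fold lower number from compound 1 to compound 2 (1.41 log units; beyond the scatter), a large step toward stronger growth inhibition. Going by the values given here, compound 2 therefore holds the lowest of the two numbers measured so far, with compound 1 the nearest to it. Compound 3, with the structure `CC(=O)N1c2ccccc2CCC1C(=O)Nc1cc(C(F)(F)F)cc(C(F)(F)F)c1`, gives only a limit of the assay, > 70000 nM, so no number is known for it; it differs from the others in more than one place, so its result cannot be tied to any single change.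

Compound 4, with the structure `O=C(Nc1ccccc1O)C1CCc2ccccc2N1C(=O)c1ccc(Cl)cc1`, is not yet measured. It differs from compound 2 in one place: (4-chlorophenyl)carbonyl in place of hydrogen on a nitrogen on an aromatic ring in a ring. Among the compounds with values here, no measured step bears directly on this change; the only step measured, from compound 1 to compound 2, concerns the hydroxy group and not the ring nitrogen. What compound 3 shows is a result at the limit of > 70000 nM in this assay, at which 1 of the 3 values shown sits, for a compound whose ring nitrogen also carries an acyl group, though other differences accompany it. With so little to go on, compound 4 is expected to give about 20000 nM, with an estimated range from 4000 nM to 100000 nM, meaning an expected step of a 4.6-fold higher number from compound 2 to compound 4 (0.67 log units; beyond the scatter).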

Compound 4, concentration for 50% growth inhibition: 25100 nM
Estimate against measurement, compound 4: 1.3-fold (0.10 log units) below; the range from low to high includes it.
By their numbers in this assay, from the lowest: compound 2; then compound 4; then compound 1.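

Going by these compounds alone, replacing the hydrogen on this ring nitrogen with (4-chlorophenyl)carbonyl gives the first measured step at this position: a 5.8-fold higher number from compound 2 to compound 4 (0.77 log units; beyond the scatter) in this assay. The change weakens growth inhibition, yet compound 4 still gives a real number, 25100 nM, so the hydrogen on this nitrogen is not needed for a measurable value in this series. Compound 3 also carries an acyl group on this nitrogen but differs in other places as well, and its result is a limit rather than a number, so it offers no second reading of this change: the limit of > 70000 nM in this assay, at which 1 of the 4 values shown sits.

With only one group tested at this nitrogen, the compounds shown leave open whether the step comes from the carbonyl, the added aromatic ring or the chlorine, a question that a plain benzoyl group or a methyl group on the same nitrogen would help to separate. As far as these compounds go, it also remains open whether the hydroxy group on the amide ring has the same large effect once the nitrogen is acylated, since that step is known only with hydrogen on the nitrogen.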